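The source may report more compounds than this note shows. Statements on the series, on what has been measured and on what is new or still open speak of the compounds shown alone.

Values measured in an ADME assay on MDBK cells (Bos taurus) for cytotoxicity, read by MTT assay, with a stated time of 96 h (on this read-out lower numbers stand for higher toxicity in this test and higher numbers for lower toxicity in this test), are as follows
- compound 1 `COc1ccc(/N=N/N2CCCC2)cc1` gives 60000 nM
- compound 2 `O=[N+]([O-])c1ccc(/N=N/N2CCCC2)cc1` gives > 100000 nM (a limit)
- compound 3 `c1ccc(/N=N/N2CCCC2)cc1` gives > 100000 nM (a limit)

Compound 3 has no number, only a limit of the assay, and it shares the limit of > 100000 nM in this assay, at which 2 of the 3 values shown sit, with one other compound. Compound 4 `Clc1ccc(/N=N/N2CCCC2)cc1` differs from it by chloro in place of hydrogen on an aromatic carbon. Among the measured compounds shown here, no measured step brings in chloro, so the closest guides are the other changes at this same place on the shared core. These are an at least 1.6-fold higher number from compound 1 to compound 3 (0.22 log units; that floor lies within the scatter) and an at least 1.6-fold higher number from compound 1 to compound 2 (0.22 log units; that floor lies within the scatter), and neither is shown to exceed the scatter. The third, a step that the two limits leave unreadable from compound 2 to compound 3, gives no usable size. In this assay, therefore, no step beyond the scatter is expected, though a limit would hide a drop of modest size. The expected step is an at least 1.1-fold lower number from compound 3 to compound 4 (0.04 log units; that floor lies within the scatter). For compound 4 the estimated value is 90000 nM, with an expected range from 35000 nM to 200000 nM.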

Compound 4, half-maximal cytotoxic concentration: > 100000 nM
Compound 4: only a limit was reported; the forecaster's own chance of this, stated with the estimate: 55%; middle value at least 1.1-fold (0.04 log units) from the limit.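

In this assay compound 4 gives > 100000 nM, which is a limit of the assay and not a number. Chloro on this aromatic carbon, para to a group of 7 heavy atoms, therefore ends at the same limit as nitro and hydrogen: the limit of > 100000 nM in this assay, at which 3 of the 4 values shown sit. Chloro in place of methoxy gives an at least 1.6-fold higher number from compound 1 to compound 4 (0.22 log units; that floor lies within the scatter), so this change is not shown to exceed the scatter, and the steps among compound 2, compound 3 and compound 4 cannot be read.

On these data alone, how far these three compounds lie from one another beyond the limit stays open. As far as these compounds go, it is also open whether an amine or an ethoxy group at this place would give a number, as methoxy does in compound 1, or would sit at the limit.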